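The source may report more compounds than this note shows. Statements on the series, on what has been measured and on what is new or still open speak of the compounds shown alone.

Working notes on the series. Compound 1 `CC(C)[C@H](NC(=O)COc1cccc2ccccc12)C(=O)N[C@@H](CC(=O)O)C(=O)COc1ccc(OC(F)(F)F)cc1` carries the shared core with a 4-(trifluoromethoxy)phenyl on an oxygen on a saturated carbon. In a functional assay on Jurkat cells (Homo sapiens) (on this read-out higher numbers stand for weaker inhibition and lower numbers for stronger inhibition), compound 1 gives 29100 nM, the highest of the two numbers in hand. Compound 2 `CC(C)[C@H](NC(=O)COc1cccc2ccccc12)C(=O)N[C@@H](CC(=O)O)C(=O)COc1c(F)ccc(F)c1F` differs from it only at that position; in this assay compound 2 gives 1200 nM. Among the compounds with values here, the one measured step is a 24-fold lower number from compound 1 to compound 2 (1.38 log units; beyond the scatter). Compound 3 `CC(C)[C@H](NC(=O)COc1cccc2ccccc12)C(=O)N[C@@H](CC(=O)O)C(=O)COc1cc(F)c(F)cc1F` is not yet measured. Its difference from compound 1 is 2,4,5-trifluorophenyl in place of 4-(trifluoromethoxy)phenyl on an oxygen on a saturated carbon. Within the data shown here, the only comparison that bears on this change is the step to compound 2, a large drop from the same starting point with another trifluorophenyl; no step between two trifluorophenyl compounds exists, so how much of that size carries over is uncertain. A large drop in this assay is nonetheless expected, somewhat smaller than the measured step. The expected step is a 12-fold lower number from compound 1 to compound 3 (1.07 log units; beyond the scatter). For compound 3 the estimate in this assay is 2500 nM, within 700 nM to 9000 nM.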

Compound 3, half-maximal inhibitory concentration: 39300 nM
For compound 3 the middle estimate is 16-fold (1.20 log units) below the measured one; the whole stated range lies below it.
By their numbers in this assay, from the lowest: compound 2; then compounds 1 and 3 (each within the scatter of the next).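

In this assay, the step of a 1.4-fold higher number from compound 1 to compound 3 (0.13 log units; within the scatter) shows that a trifluorophenyl on this oxygen does not by itself give the lower number seen with compound 2, since compound 1 and compound 3 cannot be told apart here. The step of a 33-fold higher number from compound 2 to compound 3 (1.52 log units; beyond the scatter), the first between two trifluorophenyl groups, shows that at this position the read-out depends on the fluorine pattern, 2,3,6-trifluorophenyl against 2,4,5-trifluorophenyl, and not merely on the presence of a trifluorophenyl. No measurement at hand accounts for this gap.

As far as these compounds go, whether a 2,6-difluorophenyl or an unsubstituted phenyl on this oxygen would read like compound 2 or like compound 3 remains open. From the compounds shown here alone, it is also open whether the gap between these two fluorine patterns would persist with a group other than the naphthyloxyacetyl on the shared core.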